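The source may report more compounds than this note shows. Statements on the series, on what has been measured and on what is new or still open speak of the compounds shown alone.

Three compounds set the stage. Compound 1 `O=C(O)C1CC1c1ccc(C#Cc2cc(Cl)nc(Cl)c2)cc1`, compound 2 `O=C(O)CCc1ccc(C#Cc2ncccc2[N+](=O)[O-])cc1` and compound 3 `Cc1cc(C#Cc2ccc(CCC(=O)O)cc2)ccn1` were each tested in an in vitro functional assay on 1321-N1 cells for agonist activity at Free fatty acid receptor 1 (Homo sapiens), read by fluorescence, spectrophotometry and calcium flux; on this read-out higher numbers stand for larger maximal responses and lower numbers for smaller maximal responses. In this assay compound 1 gives 96%, compound 2 gives 87% and compound 3 gives 102%. Compound 2 thus has the smallest of the three numbers, though its gap to compound 1 lies within the scatter and only its gap to compound 3 lies beyond it. Compound 4 `O=C(O)CCc1ccc(C#Cc2ccccn2)cc1` has not yet been tested. Compared with compound 2 it carries hydrogen in place of nitro on an aromatic carbon. Among the measured compounds shown here, no measured pair shows what such a change does here, so the step from compound 2 to compound 4 is expected to be small, likely within the scatter, and if anything upward, as a number 7 percentage points higher from compound 2 to compound 4 (within the scatter). Compound 4 is therefore expected to reach about 94% in this assay, with a range from 80% to 106%.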

Compound 4, largest response reached (reported as efficacy), in percent of the reference or control that the assay uses: 98%
Estimate against measurement, compound 4: 4 percentage points below; low and high end bracket the measured number.
By their numbers in this assay, from the lowest: compounds 2, 1, 4 and 3 (each within the scatter of the next, the first and the last beyond it).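

Hydrogen in place of nitro on this aromatic carbon gives a number 11 percentage points higher from compound 2 to compound 4 (beyond the scatter) in this assay, the first measured pair to show what this change does. The step is modest, and the nitro group is not needed here for a large maximal response. Nothing measured here explains the rise. From the compounds shown here alone, whether an amine or a methoxy group on this carbon would give a number closer to that of hydrogen or of nitro remains open. So does whether the same change would give a similar step on the core of compound 1.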